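The compounds below may be only part of what the source reports. "The series", "measured", "known", "first", "only" and "open" are said of these compounds alone.

Compound 1 `COc1ccc(-c2cnc(NC(=O)c3ccno3)n2C)cc1` gives > 100000 nM
Compound 2 `COc1ccc(-c2cnc(NC(=O)c3cccc(Cl)c3)n2C)cc1` gives > 28000 nM

In a toxicity assay on THP-1 cells (Homo sapiens) for inhibition (on this read-out lower numbers stand for higher toxicity in this test and higher numbers for lower toxicity in this test), compound 2 stands at > 28000 nM, and this is a limit of the assay, not a number. Compound 1 also has only a limit, > 100000 nM, so neither compound offers a numerical value to work from.

The next compound is compound 3 `COc1ccc(-c2cnc(NC(C)=O)n2C)cc1`, which carries methyl in place of 3-chlorophenyl on a carbonyl carbon.

Among the compounds with values here, the only measured step at this carbonyl carbon is a step that the two limits leave unreadable from compound 1 to compound 2. It therefore gives no size to carry over to the new change, and the data do not fix a direction either. No step beyond the usual scatter is expected in this assay, although the estimate leans slightly towards higher numbers. The estimated step is a step that the limit leaves unreadable from compound 2 to compound 3. A report of compound 3 as a limit, rather than a number, is the likely outcome. For compound 3 the expected value is 50000 nM, with an estimated range from 20000 nM to 120000 nM.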

Compound 3, half-maximal cytotoxic concentration: > 100000 nM
Compound 3: no number, only a limit; the forecaster's own chance of this, stated with the estimate: 80%; middle value at least 2.0-fold (0.30 log units) from the limit.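

In this assay compound 3 gives > 100000 nM, which is a limit of the assay and not a number. Within the data shown here, as compound 1 and compound 2 also have only limits, no step among compound 1, compound 2 and compound 3 can be read. The compounds shown leave open whether the group on the carbonyl carbon changes the half-maximal cytotoxic concentration at all, and if so in which direction and by how much.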